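Nitro for nitrile on the triazole aryl of two terpenoid cores

The source may hold more compounds than are shown below. What is called first, only, known or untested is meant among the compounds shown, and "the series" means these compounds.

Measured compounds:
compound 1 `CC(C)=CCC/C(C)=C/CC/C(C)=C/CC[C@@H]1[C@@]2(C)CC/C(=N\OCc3cn(-c4ccccc4C#N)nn3)C(C)(C)[C@@H]2CC[C@@]1(C)O` gives 21900 nM
compound 2 `CC(C)=CCC/C(C)=C/CC/C(C)=C/CC[C@@H]1[C@@]2(C)CC/C(=N\OCc3cn(-c4cccc([N+](=O)[O-])c4)nn3)C(C)(C)[C@@H]2CC[C@@]1(C)O` gives 22000 nM
compound 3 `CC(C)=CCC/C(C)=C/CC/C(C)=C/CC[C@@H]1[C@@]2(C)C/C(=C\c3ccc(OCc4cn(-c5ccccc5C#N)nn4)cc3)C(=O)C(C)(C)[C@@H]2CC[C@@]1(C)O` gives 63100 nM

All three values come from a functional assay on HepG2 cells (Homo sapiens) for cytotoxicity, read by MTT assay, with a stated time of 48 h; on this read-out higher numbers stand for weaker inhibition and lower numbers for stronger inhibition. Compound 1 and compound 2 share one core; the change between them, (3-nitrophenyl in place of 2-cyanophenyl on an aromatic nitrogen), makes the step of a 1.0-fold higher number from compound 1 to compound 2 (0.00 log units; within the scatter). Compound 3 carries a different core, and the difference between the two cores is not broken down here; in this assay compound 3 gives 63100 nM, the highest of the three numbers.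

Compound 4 `CC(C)=CCC/C(C)=C/CC/C(C)=C/CC[C@@H]1[C@@]2(C)C/C(=C\c3ccc(OCc4cn(-c5cccc([N+](=O)[O-])c5)nn4)cc3)C(=O)C(C)(C)[C@@H]2CC[C@@]1(C)O` is not yet measured. It differs from compound 3 by 3-nitrophenyl in place of 2-cyanophenyl on an aromatic nitrogen, the same change already seen between compound 1 and compound 2. Because that earlier step was a 1.0-fold higher number from compound 1 to compound 2 (0.00 log units; within the scatter), the step from compound 3 to compound 4 is expected to be small, about a 1.0-fold lower number from compound 3 to compound 4 (0.00 log units; within the scatter). Compound 4 is therefore estimated at 63000 nM, with a likely range from 30000 nM to 130000 nM.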

Compound 4, half-maximal inhibitory concentration: 117000 nM
Compound 4: middle estimate off by 1.9-fold (0.27 log units), on the low side; the range from low to high includes it.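

In this assay, putting 3-nitrophenyl in place of 2-cyanophenyl on the second core gives a 1.9-fold higher number from compound 3 to compound 4 (0.27 log units; within the scatter). Set beside the same change on the first core, the two steps do not differ by more than the measurements can resolve: the same change on two cores in this assay, a 1.0-fold higher number (0.00 log units; within the scatter) from compound 1 to compound 2 and a 1.9-fold higher number (0.27 log units; within the scatter) from compound 3 to compound 4, 1.8-fold (0.27 log units) apart, within the scatter of two such steps Within this series the change therefore carries from one core to the other without a detectable difference, but this rests on only two pairs, neither step shows a real effect of the change, and nothing here extends it to other cores or other read-outs.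

The compounds shown leave open whether an amine or a carboxylic acid on the same phenyl ring would move the number beyond the scatter on either core. They also leave open whether a longer chain at that ring nitrogen would carry across the two cores in the same way.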